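A Shorter Ether Chain Against the Cytotoxicity Ceiling

A few compounds are considered here, and "the series" means these few. Any claim that something is new, unique, unknown or untested is made for them only; others in the source may bear on it.

Three compounds share one core and differ only in the group joined to it through sulfur or oxygen. Compound 1, `CCCCSc1nc(N)nc2c1ncn2/C=C1/CC1(CO)CO`, carries a butylsulfanyl group; in an ADME assay on MOLT-3 cells (Homo sapiens) for cytotoxicity, with a stated time of 7 days (on this read-out lower numbers stand for higher toxicity in this test and higher numbers for lower toxicity in this test), compound 1 gives > 20000 nM, which is a limit of the test rather than a number. Compound 2, `CCCOc1nc(N)nc2c1ncn2/C=C1/CC1(CO)CO`, carries propoxy instead; in this assay compound 2 gives > 20000 nM, again a limit. Compound 3, `CCCCCOc1nc(N)nc2c1ncn2/C=C1/CC1(CO)CO`, carries pentyloxy; in this assay compound 3 gives > 20000 nM, also a limit, so compound 3 stands at the edge of what the test can read, with no number of its own. The steps between these compounds are therefore unreadable: a step that the two limits leave unreadable from compound 1 to compound 2, a step that the two limits leave unreadable from compound 1 to compound 3 and a step that the two limits leave unreadable from compound 2 to compound 3. What the three share is the limit of > 20000 nM in this assay, at which 3 of the 3 values shown sit.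

Compound 4, `COCCOc1nc(N)nc2c1ncn2/C=C1/CC1(CO)CO`, is the next case: methoxy in place of propyl on a saturated chain carbon, two bonds along the chain from an oxygen on an aromatic ring. For the measured compounds named here, no measured step reads, so none gives a size or a direction for this change, and the three limits leave no numbered value to start from. The expected step is a step that the limit leaves unreadable from compound 3 to compound 4, meaning no change the test could resolve. For compound 4 the estimate in this assay is 40000 nM, with a range from 15000 nM to 150000 nM, most likely reported once more as a limit.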

Compound 4, half-maximal cytotoxic concentration: > 20000 nM
Compound 4 was reported as a limit; the forecaster's own chance of this, stated with the estimate: 85%; the middle value lies beyond the limit too.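

In this assay compound 4 also reads as a limit, so its steps from compound 1, compound 2 and compound 3 cannot be read: the limit of > 20000 nM in this assay, at which 4 of the 4 values shown sit.

The compounds shown leave open what actual number any of the four would give in this assay, and whether changing the group on the shared core alters cytotoxicity at all.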